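This account rests on a few compounds, and the source may have more. Where it says the series, first, only, none or still open, it means among the compounds named here.

In a functional assay on A549 cells (Homo sapiens) for antiproliferative activity, read by MTT assay, with a stated time of 48 h (on this read-out lower numbers stand for stronger inhibition and higher numbers for weaker inhibition), three compounds on a shared core have been measured. Compound 1 `CC(C)=CCC[C@]1(C)/C=C/[C@@H](OC(=O)C=C(C)C)[C@](C)(O)/C=C/C(=O)/C(CN=[N+]=[N-])=C\C1`, with azidomethyl on a double-bonded ring carbon, gives 1720 nM. Compound 2 `CC(C)=CCC[C@]1(C)/C=C/[C@@H](OC(=O)C=C(C)C)[C@](C)(O)/C=C/C(=O)/C(C(=O)N(C)C)=C\C1`, with dimethylcarbamoyl there, gives 2700 nM. Compound 3 `CCN(CC)C(=O)/C1=C/C[C@](C)(CCC=C(C)C)/C=C/[C@@H](OC(=O)C=C(C)C)[C@](C)(O)/C=C/C1=O`, with diethylcarbamoyl there, gives 11300 nM, the highest of the three numbers and so the weakest inhibition in the set. Compound 4 `CC(C)=CCC[C@]1(C)/C=C/[C@@H](OC(=O)C=C(C)C)[C@](C)(O)/C=C/C(=O)/C(C(=O)N(C(C)C)C(C)C)=C\C1` has diisopropylamino in place of diethylamino on a carbonyl carbon. For the measured compounds named here, the closest precedent is the change from dimethylamino to diethylamino on that carbonyl carbon, a 4.2-fold higher number from compound 2 to compound 3 (0.62 log units; beyond the scatter). The azidomethyl replacements bear on it less directly, with a 1.6-fold higher number from compound 1 to compound 2 (0.20 log units; within the scatter) and a 6.6-fold higher number from compound 1 to compound 3 (0.82 log units; beyond the scatter). The trend among the amides rests on this single pair, so a further rise of modest size is expected, though with wide uncertainty. In this assay the step expected for compound 4 is a 1.8-fold higher number from compound 3 to compound 4 (0.25 log units; within the scatter), toward weaker inhibition. Compound 4 is estimated at 20000 nM, with an expected range of 8000 nM to 50000 nM.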

Compound 4, half-maximal inhibitory concentration: 13500 nM
Compound 4: middle estimate off by 1.5-fold (0.17 log units), on the high side, within the range that was stated.
By their numbers in this assay, from the lowest: compounds 1 and 2 (each within the scatter of the next); then compounds 3 and 4 (each within the scatter of the next).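

Moving from diethylamino to diisopropylamino on a carbonyl carbon in this assay gives only a small step (a 1.2-fold higher number from compound 3 to compound 4 (0.08 log units; within the scatter)), so compound 3 and compound 4 cannot be told apart, although the change from dimethylamino to diethylamino had gone beyond the scatter (a 4.2-fold higher number from compound 2 to compound 3 (0.62 log units; beyond the scatter)). Compound 4 remains clearly separated from both the dimethylamino amide (a 5.0-fold higher number from compound 2 to compound 4 (0.70 log units; beyond the scatter)) and the azidomethyl compound (a 7.8-fold higher number from compound 1 to compound 4 (0.89 log units; beyond the scatter)), so among these amides the numbers rise at the first change of amino group and show no further separation at the second. No measurement shown gives a reason for these numbers. From the compounds shown here alone, it remains open how a cyclic amine such as pyrrolidine or morpholine would behave on that carbonyl carbon. The same holds for a secondary amide or a carboxylic acid in place of these tertiary amides.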